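Fluorine Swap on a Tolerability Series of Benzofuran Esters

The source may hold more compounds than are shown below. What is called first, only, known or untested is meant among the compounds shown, and "the series" means these compounds.

Of the compounds shown here, three have been tested in an ADME assay on Vero cells (Chlorocebus sabaeus) for cytotoxicity, read by MTT assay, with a stated time of 72 h; a higher number here means that more compound is tolerated, a lower number that less compound is tolerated. Compound 3, `CCOC(=O)c1c(-c2ccc(OC)cc2)oc2ccc(OCCCCCN3C(=O)/C(=N\OC)c4ccccc43)cc12`, gives 32 ug/mL in this assay. Compound 1, `CCOC(=O)c1c(-c2ccc(OC)cc2)oc2ccc(OCCCCCN3C(=O)/C(=N\OC)c4cc(F)ccc43)cc12`, carries one change relative to compound 3: fluoro in place of hydrogen on an aromatic carbon. The step from compound 3 to compound 1 is no change at the digits printed from compound 3 to compound 1 (within the scatter), so adding the fluorine left the tolerated concentration unchanged, and compound 1 gives 32 ug/mL in this assay.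

Compound 2, `CCOC(=O)c1c(-c2ccc(OC)cc2)oc2ccc(OCCCCCCN3C(=O)/C(=N\NC(N)=S)c4ccccc43)cc12`, has a different core from compound 3; the difference between the two cores is not broken down here. In this assay compound 2 gives 8 ug/mL, the lowest of the three numbers, and its gap to both compound 1 and compound 3 lies beyond the usual scatter, so compound 2 is the least tolerated of the measured compounds.

Compound 4, `CCOC(=O)c1c(-c2ccc(OC)cc2)oc2ccc(OCCCCCCN3C(=O)/C(=N\NC(N)=S)c4cc(F)ccc43)cc12`, has not yet been measured. Compared with compound 2 it shows (fluoro in place of hydrogen on an aromatic carbon), which is the same change as the one seen from compound 3 to compound 1. Since that earlier step was no change at the digits printed from compound 3 to compound 1 (within the scatter), the step from compound 2 to compound 4 is expected to be similarly small, no change at the digits printed from compound 2 to compound 4 (within the scatter). On that basis compound 4 is estimated to give 8 ug/mL in this assay, with a plausible range from 4 ug/mL to 16 ug/mL.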

Compound 4, half-maximal cytotoxic concentration: 8 ug/mL
The estimate for compound 4 equals the measured number at the digits printed; low and high end bracket the measured number.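

In this assay, fluoro in place of hydrogen on an aromatic carbon gives no change at the digits printed from compound 2 to compound 4 (within the scatter), and set beside the earlier step, the same swap reads alike on both cores: the same change on two cores in this assay, no change at the digits printed (within the scatter) from compound 3 to compound 1 and no change at the digits printed (within the scatter) from compound 2 to compound 4, 1.0-fold (0.00 log units) apart, within the scatter of two such steps

For these two pairs, then, the result of the swap on one core would have served as a fair guide to its result on the other, even though the two cores start from clearly different tolerated concentrations. For the compounds shown here, this does not show that the swap carries over as a general rule, since it rests on only two pairs, both of which stay flat, and a change that leaves the number unmoved on both cores cannot reveal whether a change with a real effect would also transfer from one core to the other.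

The compounds shown leave open whether a different group at the same place, such as chloro, methoxy or an amine, would move the tolerated concentration on either core, and whether fluoro elsewhere on that ring would read the same. As far as these compounds go, the chain and the core change together between compound 3 and compound 2, so what a longer chain does on its own also stays open.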